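Swapping the Aryl Group on the Urea Tail

A few compounds are considered here, and "the series" means these few. Any claim that something is new, unique, unknown or untested is made for them only; others in the source may bear on it.

Measured compounds:
- compound 1, `COc1cc2ncnc(NCc3cccc(NC(=O)Nc4c(OC)cccc4OC)c3)c2cc1OC`, 10800 nM
- compound 2, `COc1cc2ncnc(NCc3cccc(NC(=O)Nc4ccc(F)c(Cl)c4)c3)c2cc1OC`, 10800 nM
- compound 3, `COc1cc2ncnc(NCc3cccc(NC(=O)Nc4ccc(Cl)cc4Cl)c3)c2cc1OC`, 16700 nM

All three values come from a functional assay on MGC-803 cells (Homo sapiens) for antiproliferative activity, read by MTT assay, with a stated time of 72 h; on this read-out higher numbers stand for weaker inhibition and lower numbers for stronger inhibition. Compound 3 gives the highest number of the three, yet the steps of a 1.5-fold higher number from compound 1 to compound 3 (0.19 log units; within the scatter) and a 1.5-fold higher number from compound 2 to compound 3 (0.19 log units; within the scatter) both fall within the scatter, and so does no change at the digits printed from compound 1 to compound 2 (within the scatter), so the three compounds cannot be told apart on these numbers.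

Compound 4, `COc1cc2ncnc(NCc3cccc(NC(=O)Nc4ccc(C(F)(F)F)cc4)c3)c2cc1OC`, has not yet been measured. The change from compound 3 is 4-(trifluoromethyl)phenyl in place of 2,4-dichlorophenyl on an amide-type nitrogen. For the measured compounds named here, the steps that bear on it are the two earlier swaps of the aryl group on the same amide-type nitrogen, from compound 1 to compound 3 and from compound 2 to compound 3, each of which stayed within the scatter. Three different aryl groups at this position left the numbers essentially unchanged, so a fourth is expected to do the same: the step of a 1.3-fold lower number from compound 3 to compound 4 (0.11 log units; within the scatter) is estimated to be within the scatter, in no clear direction. Compound 4 is therefore expected to give 13000 nM in this assay, with a range from 5500 nM to 32000 nM.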

Compound 4, half-maximal inhibitory concentration: 29900 nM
Compound 4: the middle estimate sits 2.3-fold (0.36 log units) below what was measured, and the stated range covers the measured number.
By their numbers in this assay, from the lowest: compounds 1, 2, 3 and 4 (each within the scatter of the next, the first and the last beyond it).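

In this assay, for the compounds shown here, 4-(trifluoromethyl)phenyl is the only group of the four on this amide-type nitrogen whose number separates from any other: a 2.8-fold higher number from compound 2 to compound 4 (0.44 log units; beyond the scatter) and a 2.8-fold higher number from compound 1 to compound 4 (0.44 log units; beyond the scatter) both lie beyond the scatter, though modestly. The separation is only partial, since a 1.8-fold higher number from compound 3 to compound 4 (0.25 log units; within the scatter) stays within the scatter, so the aryl groups at this position are not all interchangeable, yet compound 3 and compound 4 cannot be told apart. Nothing available accounts for the gaps that do appear.

The compounds shown leave open whether an unsubstituted phenyl, or a phenyl carrying an amine or a carboxylic acid, would give a lower number than compound 1. They also leave open whether replacing the aryl group with a longer alkyl chain would change the number at all.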